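The compounds below may be only part of what the source reports. "The series", "measured", "known", "first", "only" and "open" are said of these compounds alone.

In a functional assay on HeLa cells (Homo sapiens) for cytotoxicity, read by MTT assay (a lower number here means a stronger inhibitor, a higher number a weaker inhibitor), compound 1 `CC(=O)OCCO[C@H](CC=C(C)C)C1=CC(=O)c2c(O)ccc(O)c2C1=O` gives 41500 nM as its half-maximal inhibitory concentration. Compound 3 `CC(C)=CC[C@@H](OC(=O)CC(O)c1ccccc1)C1=CC(=O)c2c(O)ccc(O)c2C1=O` gives 44500 nM and so lies within the scatter of compound 1. Compound 2 `CCCCCCC(C)(O)CC(=O)O[C@H](CC=C(C)C)C1=CC(=O)c2c(O)ccc(O)c2C1=O` is reported as > 100000 nM and this is a limit of the assay, not a number. Compound 4 `CC(=O)OC(C)CO[C@H](CC=C(C)C)C1=CC(=O)c2c(O)ccc(O)c2C1=O` differs from compound 1 by methyl in place of hydrogen on a saturated chain carbon bound to an oxygen next to a carbonyl group and a saturated chain carbon and carries methyl in place of hydrogen on a saturated chain carbon bound to an oxygen next to a carbonyl group and a saturated chain carbon, so that 2-acetoxyethoxy becomes 2-acetoxypropoxy. Among the compounds with values here, the only measured step is an at least 2.2-fold lower number from compound 2 to compound 3 (0.35 log units; beyond the scatter) and it bears on this change only loosely. It exchanges a whole group, starts from a limit and adds no methyl. No step beyond the scatter is therefore expected in this assay, and the data favour no direction. The expected step is a 1.0-fold lower number from compound 1 to compound 4 (0.02 log units; within the scatter) and it stays within the scatter. Compound 4 is estimated at 40000 nM with a range from 18000 nM to 85000 nM expected.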

Compound 4, half-maximal inhibitory concentration: 40100 nM
The estimate for compound 4 lay 1.0-fold (0.00 log units) below the measured number; the range from low to high includes it.
By their numbers in this assay, from the lowest: compounds 4, 1 and 3 (each within the scatter of the next). At a limit, above all of these: compound 2.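

In this assay, methyl in place of hydrogen on a saturated chain carbon bound to an oxygen next to a carbonyl group and a saturated chain carbon, which turns 2-acetoxyethoxy into 2-acetoxypropoxy, gives a 1.0-fold lower number from compound 1 to compound 4 (0.01 log units; within the scatter), so this single added carbon leaves the number unchanged within the scatter. Within the data shown here, the earlier compounds could not show this, since the only earlier step exchanged a whole group and started from a limit, whereas this one reads a single position directly. Nothing shown here offers a cause for this result.

What the compounds leave open is whether a larger group at this carbon, such as an ethyl or a phenyl, or an amine or a hydroxyl there, would also stay within the scatter. Also open, on these data alone, is what a carboxylic acid or an amide in place of the acetoxy end would do.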